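The compounds below may be only part of what the source reports. "The series", "measured", "known", "first", "only" and "open" are said of these compounds alone.

Measured so far:
- compound 1, `N#CC1=C(N)Oc2c(c3nc4ccccc4nc3c3ccccc23)C12C(=O)N(Cc1cnnn1-c1ccccc1Cl)c1ccccc12`, in a functional assay on MCF7 cells (Homo sapiens) for antiproliferative activity, read by MTT assay, with a stated time of 48 h (on this read-out lower numbers stand for stronger inhibition and higher numbers for weaker inhibition), gives > 50000 nM, which is a limit of the assay and not a number.
- compound 2, `COc1ccc(-n2nncc2CN2C(=O)C3(C(C#N)=C(N)Oc4c(N)cc5nc6ccccc6nc5c43)c3ccccc32)cc1`, in this assay gives > 50000 nM, again a limit rather than a number.

Compound 2 therefore stands at the limit of > 50000 nM in this assay, at which 2 of the 2 values shown sit. Compound 3, `Cc1ccc(Cl)cc1-n1nncc1CN1C(=O)C2(C(C#N)=C(N)Oc3c(N)cc4nc5ccccc5nc4c32)c2ccccc21`, is not yet measured; it differs from compound 2 by 5-chloro-2-methylphenyl in place of 4-methoxyphenyl on an aromatic nitrogen. Among the measured compounds shown here, with no measured step to lean on, no change beyond the scatter is expected, and the step of a number no higher from compound 2 to compound 3 (the limit leaves the size open) is an estimate only. Compound 3 is expected to give about 50000 nM in this assay, within 20000 nM to 100000 nM.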

Compound 3, half-maximal inhibitory concentration: 43500 nM
Estimate against measurement, compound 3: 1.1-fold (0.06 log units) above; measured number inside the range.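

In this assay, among the compounds shown here, compound 3 gives 43500 nM, the first measured number in this set rather than a limit, so a compound with this group on the aromatic nitrogen does register in the assay. From the compounds shown here alone, the change to 5-chloro-2-methylphenyl is an at least 1.1-fold lower number from compound 2 to compound 3 (0.06 log units; that floor lies within the scatter), and its true size stays open. Most values shown are still limits: the limit of > 50000 nM in this assay, at which 2 of the 3 values shown sit.

Going by these compounds, the chlorine and the methyl enter together, so their separate contributions remain unknown. On these data alone, it also remains open how an amine or a carboxylic acid at this position would read.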